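The source may hold more compounds than are shown below. What is called first, only, known or untested is meant among the compounds shown, and "the series" means these compounds.

Three compounds on the shared core have been run in an assay for inhibition of Alpha amylase (Homo sapiens), with a stated time of 30 min; a lower number here means a stronger inhibitor, a higher number a weaker inhibitor. Compound 1 `CCOC(=O)c1c(-c2ccccc2)nn(-c2ccccc2)c1Cn1cnc2cc(C)ccc21` gives 45 ug/mL. Compound 2 `CCOC(=O)c1c(-c2ccccc2)nn(-c2ccccc2)c1Cn1c(S)nc2ccccc21` gives 40 ug/mL, and compound 3 `CCOC(=O)c1c(-c2ccccc2)nn(-c2ccccc2)c1COCc1ccccc1` gives 45 ug/mL. Compound 1 stands level with compound 3 at the digits reported, the two together holding the highest of the three numbers; its nearest neighbour is compound 3 and its furthest compound 2. The steps of a 1.1-fold lower number from compound 1 to compound 2 (0.05 log units; within the scatter) and no change at the digits printed from compound 1 to compound 3 (within the scatter) both stay within the scatter, as does a 1.1-fold higher number from compound 2 to compound 3 (0.05 log units; within the scatter).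

The next compound, compound 4 `CCOC(=O)c1c(-c2ccccc2)nn(-c2ccccc2)c1COc1ccccc1C=O`, differs from compound 1 in one place: 2-formylphenoxy in place of 5-methyl-1H-benzimidazol-1-yl on a saturated chain carbon bound to an aromatic carbon. The step from compound 1 to compound 3 bears most directly on this change, since it also replaces 5-methyl-1H-benzimidazol-1-yl on the same saturated chain carbon, there by benzyloxy, and showed no change at the digits reported. The step from compound 1 to compound 2, which exchanges that group for another at the same carbon, was likewise within the scatter. For the measured compounds named here, nothing measured so far separates the groups tried at this position, so no step beyond the scatter is expected in this assay. Compound 4 is therefore expected at 45 ug/mL, within 25 ug/mL to 80 ug/mL, which means an estimated step of no change at the digits printed from compound 1 to compound 4 (within the scatter).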

Compound 4, half-maximal inhibitory concentration: 40 ug/mL
Beside the measured number, compound 4's estimate is 1.1-fold (0.05 log units) above it; the measured number falls inside the stated range.
By their numbers in this assay, from the lowest: compounds 2, 4, 1 and 3 (each within the scatter of the next).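

In this assay the series now holds a member whose entering group, 2-formylphenoxy, has one six-membered aromatic ring of carbon only and a double bond outside aromatic rings in place of the two-ring 5-methyl-1H-benzimidazol-1-yl, and this exchange gives a 1.1-fold lower number from compound 1 to compound 4 (0.05 log units; within the scatter) and so adds a third replacement at this carbon that stays within the scatter. The two neighbouring comparisons agree: 2-formylphenyl in place of benzyl on the oxygen gives a 1.1-fold lower number from compound 3 to compound 4 (0.05 log units; within the scatter) and the exchange against the sulfur-bearing group of compound 2 gives no change at the digits printed from compound 2 to compound 4 (within the scatter) so all four compounds remain unseparated, and the formyl group brings no step beyond the scatter in this set. No measurement on hand accounts for this flat response at the saturated chain carbon.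

The compounds shown leave open whether any group at this carbon can move the number beyond the scatter, since all four entering groups carry an aromatic ring and none is charged. A carboxylic acid or a piperidine on this carbon, or a longer chain between it and the aromatic ring, would test that limit directly.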